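Swapping Cyclobutylamino for Dimethylamino at an Aromatic Carbon

A few compounds are considered here, and "the series" means these few. Any claim that something is new, unique, unknown or untested is made for them only; others in the source may bear on it.

Compound 1 `CCCc1cc(NC2CCC2)c2cc(NC(=O)/C=C/c3ccc(C(F)(F)F)cc3)ccc2n1` gives 270 nM in a functional assay on HEK293 cells for activation of melanin-concentrating hormone receptor 1 (Homo sapiens), read by inositol phosphate accumulation; a lower number here means that less compound is needed, a higher number that more compound is needed for the effect.
Compound 2 `CCCc1cc(N)c2cc(NC(=O)/C=C/c3ccc(F)cc3)ccc2n1` gives 200 nM in this assay.
Compound 3 `CCCc1cc(N)c2cc(NC(=O)/C=C/c3ccccc3Cl)ccc2n1` gives 500 nM in this assay.

Compound 1 stands second highest of the three numbers. Its nearest neighbour is compound 2, within the usual scatter, and its furthest is compound 3, also still within the scatter, so none of the three can be called stronger or weaker than the others.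

Compound 4 `CCCc1cc(N(C)C)c2cc(NC(=O)/C=C/c3ccc(C(F)(F)F)cc3)ccc2n1` has not been measured. It is reached from compound 1 by one change: dimethylamino in place of cyclobutylamino on an aromatic carbon. Among the measured compounds shown here, the only measured step, a 2.5-fold higher number from compound 2 to compound 3 (0.40 log units; beyond the scatter), changes the aryl group at the far end of the double-bonded chain and leaves the amino substituent untouched, so it does not bear on this change. Compounds 2 and 3 carry a plain amino group where compound 1 carries cyclobutylamino, but each differs from compound 1 in two places, so their values show only that all three lie close together.

For the measured compounds named here, with no step that isolates the amino substituent, compound 4 is expected to sit near compound 1, with the estimated step of a 1.1-fold higher number from compound 1 to compound 4 (0.05 log units; within the scatter) not beyond the scatter. Compound 4 is estimated at 300 nM, between 120 nM and 800 nM.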

Compound 4, half-maximal effective concentration: 300 nM
Compound 4: the middle estimate sits on the measured number at the digits printed; the range from low to high includes it.
By their numbers in this assay, from the lowest: compounds 2, 1, 4 and 3 (each within the scatter of the next, the first and the last beyond it).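

Among the compounds shown here, the step of a 1.1-fold higher number from compound 1 to compound 4 (0.05 log units; within the scatter) is the first one that isolates the substituent on this aromatic carbon, opposite the ring nitrogen, and in this assay it cannot be told apart from no change. The exchange is not a small one on paper: cyclobutylamino, with 5 heavy atoms, a four-membered ring and 1 hydrogen-bond donor, gives way to dimethylamino, with 3 heavy atoms, no ring and 0 hydrogen-bond donors, so for this pair, with the rest of the molecule held fixed, losing the ring and the donor together leaves the number within the scatter. No measurement is available that could explain this outcome.

On these data alone, two compounds cannot show how far this tolerance reaches, so it remains open whether a piperidine or morpholine ring, a longer chain such as dipropylamino, or a methoxy group with no nitrogen on this carbon would read the same. As far as these compounds go, it also remains open whether the plain amino group of compounds 2 and 3 would match cyclobutylamino and dimethylamino with the 4-trifluoromethylphenyl end of compound 1 kept in place.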